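The compounds below may be only part of what the source reports. "The series", "measured", "known", "first", "only" and "open" are said of these compounds alone.

Working notes on the series. In an ADME assay on L6 cells (Rattus norvegicus) for cytotoxicity (a higher number here means a weaker inhibitor, a lower number a stronger inhibitor), compound 1 `O=C(CN1CCN(c2ccc(Cl)cc2)CC1)N1CCN(c2ccc(Cl)cc2)CC1` gives 116000 nM and compound 2 `N#Cc1ccccc1N1CCN(C(=O)Cn2cnc([N+](=O)[O-])n2)CC1` gives 213000 nM so these two numbers lie within the scatter of each other, and compound 2 stands level with compound 1 on the data so far. Compound 3 `O=C(Cn1cnc([N+](=O)[O-])n1)N1CCN(c2ccc(Cl)cc2)CC1` is still unmeasured. It has 4-chlorophenyl in place of 2-cyanophenyl on an amine nitrogen in a ring and otherwise matches compound 2. Within the data shown here, no measured pair shows this change. The 4-chlorophenyl group also occurs in compound 1 (116000 nM) but that compound differs from compound 3 elsewhere too, so it is only a loose guide. In this assay a modest move to a lower number is expected, possibly none beyond the scatter. The expected size is a 1.6-fold lower number from compound 2 to compound 3 (0.21 log units; within the scatter). Nothing in the data so far narrows this. For compound 3 the estimated value is 130000 nM with 60000 nM to 280000 nM as the expected range.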

Compound 3, half-maximal inhibitory concentration: > 285000 nM
Compound 3 gave a limit, no number (the forecaster's own chance of this, stated with the estimate: 10%); middle value at least 2.1-fold (0.34 log units) from the limit.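

In this assay, among these compounds, 4-chlorophenyl in place of 2-cyanophenyl on an amine nitrogen in a ring gives an at least 1.3-fold higher number from compound 2 to compound 3 (0.12 log units; that floor lies within the scatter), and this is the only reading of the change. Compound 3 gave a limit and not a number: the limit of > 285000 nM in this assay, at which 1 of the 3 values shown sits. The step is therefore only a floor: it shows no move to a lower number with this change, but it does not fix how large the change is or show that it lies beyond the scatter.

Open, from the compounds shown here alone, is whether the two aryl groups differ at all in this assay once compound 3 has a number. Also open, going by these compounds, is whether a plain phenyl, a 4-methoxyphenyl or a 4-aminophenyl on the same ring nitrogen would shift the reading beyond the scatter.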